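The source may report more compounds than this note shows. Statements on the series, on what has been measured and on what is new or still open speak of the compounds shown alone.

The series below is judged in a functional assay on SW480 cells (Homo sapiens) for cytotoxicity, read by MTT assay, with a stated time of 4 days; on this read-out lower numbers stand for stronger inhibition and higher numbers for weaker inhibition. Compound 2 `C=C1C(=O)[C@]23C[C@@]1(O)CC[C@H]2c1ccc(O)c(C)c1[C@@H]3Cn1cc(-c2ccc(F)cc2)nn1` gives 250 nM. Compound 1 `C=C1C(=O)[C@]23C[C@@]1(O)CC[C@H]2c1ccc(O)c(C)c1[C@@H]3Cn1cc(-c2ccccn2)nn1` gives 410 nM. The two differ by one change, (pyridin-2-yl in place of 4-fluorophenyl on an aromatic carbon), and the measured step is a 1.6-fold higher number from compound 2 to compound 1 (0.21 log units; within the scatter). On this evidence, exchanging the 4-fluorophenyl group for the pyridin-2-yl group leaves the growth-inhibiting potency essentially unchanged.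

Compound 3 `C=C1C[C@]23C[C@@]1(O)CC[C@H]2c1cc(Br)c(O)c(C)c1[C@@H]3Cn1cc(-c2ccc(F)cc2)nn1` is a different case. Compound 3 reaches only > 20000 nM in this assay, which is a limit of the assay rather than a number, as the limit of > 20000 nM in this assay, at which 1 of the 3 values shown sits, records. How the core of compound 3 differs from the core of compound 2 is not broken down here.

Compound 4 `C=C1C[C@]23C[C@@]1(O)CC[C@H]2c1cc(Br)c(O)c(C)c1[C@@H]3Cn1cc(-c2ccccn2)nn1` has not yet been measured. It differs from compound 3 by pyridin-2-yl in place of 4-fluorophenyl on an aromatic carbon, the same change that carries compound 2 to compound 1, at the same place on the five-membered aromatic ring with 3 nitrogen. The expectation for compound 4 therefore rests on the step seen between compounds 2 and 1, a 1.6-fold higher number from compound 2 to compound 1 (0.21 log units; within the scatter), which is small, and on the fact that compound 3 already sits at a limit. Compound 4 is expected to show a step that the limit leaves unreadable from compound 3 to compound 4 from compound 3. The estimated potency of compound 4 in this assay is 30000 nM, likely spanning 10000 nM to 100000 nM, with a real chance that only a limit is reported again.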

Compound 4, half-maximal inhibitory concentration: > 20000 nM
Compound 4 was reported as a limit (the forecaster's own chance of this, stated with the estimate: 80%); the middle value is on the limit's open side.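

Compound 3 and compound 4 are both reported only as limits in this assay, so no step can be read between them: the limit of > 20000 nM in this assay, at which 2 of the 4 values shown sit.

The compounds shown leave open whether pyridin-2-yl in place of 4-fluorophenyl makes any difference on the core shared by compound 3 and compound 4, and how far the true potency of either compound lies beyond the limit.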